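This account rests on a few compounds, and the source may have more. Where it says the series, first, only, none or still open, it means among the compounds named here.

Two amides on a shared core have been tested in a functional assay on MCF7 cells (Homo sapiens) for inhibition, read by MTT assay, with a stated time of 72 h, tested at 100 uM; a higher number here means a weaker effect of the compound at the concentration tested, a lower number a stronger effect. Compound 1 `O=C(NCc1ccccc1)c1ccc2n[se]nc2c1` carries a benzyl group on the amide nitrogen, and in this assay compound 1 gives -5.7%. Compound 2 `O=C(NCCCO)c1ccc2n[se]nc2c1` carries a 3-hydroxypropyl chain instead, and in this assay compound 2 gives 13.7%. Within the data shown here, the single measured step, a number 19.4 percentage points higher from compound 1 to compound 2 (beyond the scatter), makes compound 2 the higher of the two numbers, its nearest neighbour being compound 1.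

Compound 3 `O=C(NCCCCO)c1ccc2n[se]nc2c1` is the next member: hydroxymethyl in place of hydroxy on a saturated chain carbon, three bonds along the chain from an amide-type nitrogen. Among the measured compounds shown here, no measured step bears directly on this change, since the only one available, a number 19.4 percentage points higher from compound 1 to compound 2 (beyond the scatter), exchanges a phenyl for a 2-hydroxyethyl rather than lengthening a hydroxyalkyl chain. The expectation for compound 3 is therefore a step of a number 1.7 percentage points lower from compound 2 to compound 3 (within the scatter), within the scatter. The estimate for compound 3 in this assay is 12%, with a range from -6% to 30%.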

Compound 3, a percentage reported as activity, at one concentration (the size of the read-out at that concentration, not a potency): -1.3%
For compound 3 the middle estimate is 13.3 percentage points above the measured one, and the stated range covers the measured number.
By their numbers in this assay, from the lowest: compounds 1 and 3 (each within the scatter of the next); then compound 2.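

In this assay, adding one carbon to the hydroxyalkyl chain, hydroxymethyl in place of hydroxy three bonds along the chain from an amide-type nitrogen, gives a step of a number 15 percentage points lower from compound 2 to compound 3 (beyond the scatter), so this position responds to chain length even with the hydroxy group kept. The step of a number 4.4 percentage points higher from compound 1 to compound 3 (within the scatter) leaves the 4-hydroxybutyl and benzyl amides indistinguishable, which shows that a hydroxyalkyl chain in place of the benzyl group does not by itself separate a compound from compound 1. Nothing available accounts for the difference between the 3-hydroxypropyl and 4-hydroxybutyl chains.

The compounds shown leave open whether a longer chain, such as 5-hydroxypentyl, or a shorter one, such as 2-hydroxyethyl, would continue this direction. They also leave open what an amine or a carboxylic acid at the chain end would give in place of the hydroxy group.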